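This account rests on a few compounds, and the source may have more. Where it says the series, first, only, none or still open, it means among the compounds named here.

Compound 1 `FC(F)(F)c1cccc(Cn2c(Cl)nc3cc(Cl)c(Cl)cc32)c1` and compound 2 `O=[N+]([O-])c1cccc(Cn2c(Cl)nc3cc(Cl)c(Cl)cc32)c1` share one core and differ only by nitro in place of trifluoromethyl on an aromatic carbon. In a functional assay on KB cells (Homo sapiens) for inhibition (on this read-out lower numbers stand for stronger inhibition and higher numbers for weaker inhibition), compound 1 gives only a limit of the assay, > 100000 nM. In this assay compound 2 gives 239000 nM. The step that the limit leaves unreadable from compound 1 to compound 2 cannot be sized because the limit of > 100000 nM in this assay, at which 2 of the 3 values shown sit, hides where the starting compound truly lies. Compound 3 `FC(F)(F)c1ccc(Cn2c(Br)nc3cc(Cl)c(Cl)cc32)cc1` carries another core; the difference between the two cores is not broken down here. In this assay compound 3 likewise gives only a limit, > 100000 nM. Compound 4 `O=[N+]([O-])c1ccc(Cn2c(Br)nc3cc(Cl)c(Cl)cc32)cc1` has not yet been measured; it differs from compound 3 by nitro in place of trifluoromethyl on an aromatic carbon. Within the data shown here, this is the same kind of change as the one between compound 1 and compound 2, although the surroundings differ: meta to a large group in the first pair, para to a large group in the second. With the measured step unreadable and the starting point itself a limit, the expected step is a step that the limit leaves unreadable from compound 3 to compound 4. Compound 4 is expected near 200000 nM, likely between 80000 nM and 600000 nM, with a real chance that only a limit is reported.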

Compound 4, half-maximal inhibitory concentration: 40000 nM
Estimate against measurement, compound 4: 5.0-fold (0.70 log units) above; the measured number lies below the stated range.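

In this assay, nitro in place of trifluoromethyl, para to a large group, gives an at least 2.5-fold lower number from compound 3 to compound 4 (0.39 log units; beyond the scatter), so on this core the change goes with stronger inhibition, though only a minimum can be given for the size of the step. The same change on the core of compound 1 cannot be read, so there is no second size to set beside this one, and the pair gives no proof that the effect carries from one core to the other, because the starting compound of each pair sits at a limit: the limit of > 100000 nM in this assay, at which 2 of the 4 values shown sit. One readable step on one core is no rule for the series, and it does not say why the number moved.

Among the compounds shown, only trifluoromethyl and nitro stand at this place, so it remains open how a nitrile, an amine or a carboxylic acid there would read. On these data alone, it also remains open how the two cores compare when they carry the same group at the same place.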